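The source may hold more compounds than are shown below. What is called first, only, known or untested is meant among the compounds shown, and "the series" means these compounds.

The account concerns a short series tested in a functional assay on PC-3 cells (Homo sapiens) for antiproliferative activity, read by MTT assay, with a stated time of 72 h; on this read-out lower numbers stand for stronger inhibition and higher numbers for weaker inhibition. Compound 1, `O=C(COc1ccc(C(=O)/C=C/c2ccc(Cl)cc2Cl)cc1)N[C@H]1CCOC1=O`, gives 8040 nM in this assay, and that is the lowest of the two numbers measured. Among the measured compounds shown here, compound 2, `CCOc1ccccc1OCCSC(=S)N[C@H]1CCOC1=O`, gives 24100 nM in this assay, a number that lies beyond the usual scatter above the one for compound 1; since no step between these two compounds is worked out here, only their two values can be compared.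

The unmeasured member is compound 3, `O=C(COc1ccc(C(=O)/C=C/c2ccccc2Br)cc1)N[C@H]1CCOC1=O`, which differs from compound 1 in one place: 2-bromophenyl in place of 2,4-dichlorophenyl on a double-bonded chain carbon bound to a double-bonded chain carbon. The rest of the shared core, including the lactone-bearing amide and the double-bonded chain, is unchanged.

For the measured compounds named here, no measured pair in this set shows what such a change does, so the expectation rests on the change itself and on the value of compound 1. The halogen pattern on the aromatic ring is altered while everything else stays the same, so a step within or close to the scatter is expected, with a slight lean toward a higher number; the expected step is a 1.5-fold higher number from compound 1 to compound 3 (0.17 log units; within the scatter). Compound 3 is therefore estimated at 12000 nM in this assay, with a likely range from 4000 nM to 36000 nM.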

Compound 3, half-maximal inhibitory concentration: 3260 nM
Compound 3: middle estimate off by 3.7-fold (0.57 log units), on the high side; measured number outside the range, below it.
By their numbers in this assay, from the lowest: compound 3; then compound 1; then compound 2.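

In this assay, 2-bromophenyl in place of 2,4-dichlorophenyl on a double-bonded chain carbon bound to a double-bonded chain carbon gives a 2.5-fold lower number from compound 1 to compound 3 (0.39 log units; beyond the scatter), which places this change on the side of stronger inhibition. Among the compounds shown here, until now, the series held no pair differing in one place, so nothing showed how this position responds; this step shows that changing the aryl group alone, with the rest of the shared core kept, can move the number beyond the usual scatter, and that 2,4-dichlorophenyl is not required for the activity of this series. No measured information at hand accounts for the direction or size of this step.

The bromine and the halogen pattern change together in this single exchange, so the compounds shown cannot separate the part played by the identity of the halogen from the part played by its placement on the ring. As far as these compounds go, it also remains open how a plain phenyl, or a phenyl ring carrying a methoxy or a nitrile group, would compare at this place on the same chain.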